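Benzyl ring substituent swap in the arylpiperazine urea series

The source may report more compounds than this note shows. Statements on the series, on what has been measured and on what is new or still open speak of the compounds shown alone.

Compound 1 `COc1ccccc1N1CCN(CCNC(=O)/N=N/c2ccc(F)cc2)CC1` is the simplest member of the set; in an assay on CHO cells for displacement of a labelled ligand from D(4) dopamine receptor (Homo sapiens), read by radioligand binding (on this read-out lower numbers stand for stronger inhibition and higher numbers for weaker inhibition), compound 1 gives 36 nM. Compound 2 `COc1ccccc1N1CCN(CCNC(=O)NN(Cc2ccccc2)c2ccc(F)cc2)CC1` carries a benzyl group on the hydrazine nitrogen and in this assay compound 2 gives 9 nM. Compound 3 `COc1ccccc1N1CCN(CCCNC(=O)NN(Cc2ccccc2F)c2ccc(F)cc2)CC1` lengthens the linker by one chain carbon and bears a fluorine on the benzyl ring; in this assay compound 3 gives 3.6 nM, the lowest of the three numbers. Its gap to compound 2 and its larger gap to compound 1 both lie beyond the usual scatter, so compound 3 stands as the most potent of the measured compounds.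

Compound 4 `COc1cccc(CN(NC(=O)NCCCN2CCN(c3ccccc3OC)CC2)c2ccc(F)cc2)c1` keeps the three-carbon linker and the urea of compound 3 and differs only on the benzyl ring: 3-methoxyphenyl in place of 2-fluorophenyl on a saturated chain carbon bound to a nitrogen on an aromatic ring. Within the data shown here, no pair of measured compounds differs at this position alone, so no measured step of this kind is available for comparison. Given that the change sits on the outer benzyl ring and leaves the core untouched, the step is expected to be small, with no clear direction beyond the scatter. In this assay compound 4 is expected to give 5 nM, in a range from 2 nM to 13 nM. The expected step of a 1.4-fold higher number from compound 3 to compound 4 (0.14 log units; within the scatter) is estimated to remain within the usual scatter.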

Compound 4, inhibition constant: 5.9 nM
Compound 4: middle estimate off by 1.2-fold (0.07 log units), on the low side; low and high end bracket the measured number.
By their numbers in this assay, from the lowest: compounds 3, 4 and 2 (each within the scatter of the next, the first and the last beyond it); then compound 1.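

In this assay, among these compounds, replacing 2-fluorophenyl with 3-methoxyphenyl on a saturated chain carbon bound to a nitrogen on an aromatic ring gives a 1.6-fold higher number from compound 3 to compound 4 (0.21 log units; within the scatter), the only step that isolates this position. The binding read-out therefore does not separate the two groups, even though 3-methoxyphenyl carries a hydrogen-bond acceptor that 2-fluorophenyl lacks, so on this single pair the outer ring accepts this exchange of substituent and ring position without a change beyond the scatter. No supporting measurement is available to explain this result.

With both the substituent and its place on the ring changing in this one step, the separate contributions of the fluorine, the methoxy group and their ring positions remain unresolved, and a single pair cannot show how far this tolerance extends. Also open, from the compounds shown here alone, is whether the same holds for groups of a different kind on this ring, such as a carboxylic acid, an aminomethyl group or a longer alkoxy chain, and what a plain benzyl group would give on the three-carbon linker.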